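Aryl-triazole carboxamides in MCF7 growth inhibition: working notes

The source may report more compounds than this note shows. Statements on the series, on what has been measured and on what is new or still open speak of the compounds shown alone.

compound 1 `CC(C)n1ncc2c(C(=O)NCc3cn(-c4ccc(F)cc4)nn3)cccc21`: > 40000 nM in a functional assay on MCF7 cells (Homo sapiens) for inhibition, read by MTT assay, with a stated time of 72 h (on this read-out lower numbers stand for stronger inhibition and higher numbers for weaker inhibition), a limit of the assay and not a number
compound 2 `Cc1ccc(-n2cc(CNC(=O)c3cccc4c3cnn4C(C)C)nn2)cc1`: > 40000 nM in this assay, a limit
compound 3 `Cc1ccccc1-n1cc(CNC(=O)c2cccc3c2cnn3C(C)C)nn1`: > 40000 nM in this assay, a limit

All three values sit at the same limit (the limit of > 40000 nM in this assay, at which 3 of the 3 values shown sit). The cores of compound 2 and compound 3 differ by 2-methylphenyl in place of 4-methylphenyl on an aromatic nitrogen, and a step that the two limits leave unreadable from compound 2 to compound 3 is left unreadable by the two limits. The change fluoro in place of methyl on an aromatic carbon gave a step that the two limits leave unreadable from compound 2 to compound 1, again unreadable. Compound 4 `CC(C)n1ncc2c(C(=O)NCc3cn(-c4ccccc4F)nn3)cccc21` is not yet measured and carries the same kind of change, (fluoro in place of methyl on an aromatic carbon); the place differs in that here it is ortho to a large group, while in the earlier change it is para to a large group. Compound 3 gives only a limit, > 40000 nM. With no readable step anywhere in the set, compound 4 is expected to return another limit, estimated around 40000 nM, with a range from 15000 nM to 100000 nM, which means an expected step of a number no higher from compound 3 to compound 4 (the limit leaves the size open).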

Compound 4, half-maximal inhibitory concentration: > 40000 nM
Compound 4 gave a limit, no number; the forecaster's own chance of this, stated with the estimate: 85%; the middle value sits exactly at the limit.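

Compound 4 returns a limit, as do compound 1, compound 2 and compound 3, so no step among them can be read: the limit of > 40000 nM in this assay, at which 4 of the 4 values shown sit.

The compounds shown leave open whether changing the substituted phenyl group on the shared core shifts inhibition at all, and by how much.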